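Swapping a phosphate for an amino acid on a sulfonamide core

This account rests on a few compounds, and the source may have more. Where it says the series, first, only, none or still open, it means among the compounds named here.

Measured compounds:
- compound 1, `COc1ccc(NS(=O)(=O)/C=C/c2c(F)c(F)c(F)c(F)c2F)cc1`: 10000 nM
- compound 2, `COc1cc(OC)c(/C=C/S(=O)(=O)Nc2ccc(OC)c(OC(=O)C(C)(C)C3=C(C)C(=O)C=C(C)C3=O)c2)c(OC)c1`: 9 nM
- compound 3, `COc1cc(OC)c(/C=C/S(=O)(=O)Nc2ccc(OC)c(OP(=O)(O)O)c2)c(OC)c1`: 40 nM

These values come from a functional assay on DU-145 cells (Homo sapiens) for cytotoxicity, read by trypan blue exclusion, with a stated time of 96 h; a lower number here means a stronger inhibitor, a higher number a weaker inhibitor. Compound 3 holds the second highest of the three numbers: its nearest neighbour is compound 2, whose number is lower by a margin beyond the scatter, while compound 1 lies far higher. Compound 4, `COc1cc(OC)c(/C=C/S(=O)(=O)Nc2ccc(OC)c(NC(C(=O)O)c3ccc(Br)cc3)c2)c(OC)c1`, has not yet been tested. It differs from compound 3 in one place: a group of 12 heavy atoms (8 carbon, 1 nitrogen, 2 oxygen, 1 bromine; one six-membered aromatic ring of carbon only) in place of a group of 5 heavy atoms (4 oxygen, 1 phosphorus; no ring), on an aromatic carbon. Within the data shown here, no measured pair shows what such a swap does, so the step from compound 3 to compound 4 is estimated as small, perhaps not beyond the scatter, with a 1.3-fold higher number from compound 3 to compound 4 (0.10 log units; within the scatter). Compound 4 is expected to give about 50 nM, within a range from 10 nM to 300 nM.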

Compound 4, half-maximal inhibitory concentration: 250 nM
The estimate for compound 4 lay 5.0-fold (0.70 log units) below the measured number, and the stated range covers the measured number.
By their numbers in this assay, from the lowest: compound 2; then compound 3; then compound 4; then compound 1.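

Among these compounds, this is the first direct reading of this position on the shared core. In this assay, replacing the phosphate with ((4-bromophenyl)(carboxy)methyl)amino gives a 6.3-fold higher number from compound 3 to compound 4 (0.80 log units; beyond the scatter), so the larger ring-bearing group is tolerated here only with some loss of inhibition. Nothing available explains this loss.

On these data alone, it remains open how much of the step belongs to the bromine, the carboxylic acid or the linking nitrogen. Also unknown is whether a plain amine or a hydroxyl group on this aromatic carbon would give a number closer to that of compound 3 or compound 4.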